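An alkenyl ether exchanged for a fluorinated benzyl ether

A few compounds are considered here, and "the series" means these few. Any claim that something is new, unique, unknown or untested is made for them only; others in the source may bear on it.

Of the compounds shown here, three sharing one core have been tested in a functional assay on HepG2 cells (Homo sapiens) for antiproliferative activity, read by MTT assay, with a stated time of 24 h; a higher number here means a weaker inhibitor, a lower number a stronger inhibitor. Compound 1, `COc1cc(OC)c(-c2coc3cc(OCC=C(C)C)ccc3c2=O)cc1OC`, gives 280 nM. Compound 2, `C#CCOc1ccc2c(=O)c(-c3cc(OC)c(OC)cc3OC)coc2c1`, gives 4950 nM. For compound 3, `COc1cccc(C(=O)Oc2ccc3c(=O)c(-c4cc(OC)c(OC)cc4OC)coc3c2)c1`, the assay reports only a limit, > 10000 nM. Among the numbers shown, compound 1 stands lowest, and its nearest neighbour is an 18-fold higher number from compound 1 to compound 2 (1.25 log units; beyond the scatter).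

Compound 4, `COc1cc(OC)c(-c2coc3cc(OCc4cccc(F)c4)ccc3c2=O)cc1OC`, has not yet been measured in this assay. Relative to compound 1 it carries 3-fluorophenyl in place of 2-methylprop-1-en-1-yl on a saturated chain carbon bound to an oxygen on an aromatic ring. Two measured steps alter the same side chain of compound 1 and both bear on this change: an 18-fold higher number from compound 1 to compound 2 (1.25 log units; beyond the scatter), and an at least 35-fold higher number from compound 1 to compound 3 (1.55 log units; beyond the scatter). Compound 3 sits at the limit of > 10000 nM in this assay, at which 1 of the 3 values shown sits. Both departures from the 2-methylprop-1-en-1-yl group of compound 1 weaken inhibition by a large margin, though neither introduces a six-membered aromatic ring on the saturated chain carbon, so the size of the step for compound 4 is uncertain. A weakening beyond the scatter is expected for compound 4, a 5.4-fold higher number from compound 1 to compound 4 (0.73 log units; beyond the scatter). Compound 4 is therefore estimated at 1500 nM, with a range from 400 nM to 6000 nM.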

Compound 4, half-maximal inhibitory concentration: 1230 nM
Estimate against measurement, compound 4: 1.2-fold (0.09 log units) above, and the stated range covers the measured number.
By their numbers in this assay, from the lowest: compound 1; then compound 4; then compound 2. At a limit, above all of these: compound 3.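

In this assay, a six-membered aromatic ring can sit on the saturated chain carbon bound to an oxygen on an aromatic ring at only a modest cost: 3-fluorophenyl in place of 2-methylprop-1-en-1-yl gives a 4.4-fold higher number from compound 1 to compound 4 (0.64 log units; beyond the scatter), whereas the earlier changes to this side chain gave large steps. The same ring also improves on ethynyl at that carbon, with a 4.0-fold lower number from compound 2 to compound 4 (0.60 log units; beyond the scatter), so among these ethers the one with the most heavy atoms in its side chain is not the weakest, although the smaller 3-methylbut-2-en-1-yl ether of compound 1 still gives the lowest number. Compound 3 and compound 4 both carry such a ring, so a ring alone does not settle the outcome, yet the change of (3-methoxyphenyl)carbonyl to 3-fluorobenzyl gives an at least 8.1-fold lower number from compound 3 to compound 4 (0.91 log units; beyond the scatter), which is only a floor because compound 3 stands at a limit of the assay: the limit of > 10000 nM in this assay, at which 1 of the 4 values shown sits.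

The compounds shown include neither a plain benzyl nor a 4-fluorobenzyl group, so what the fluorine contributes, and whether its place on the ring matters, stays open. On these data alone, how a longer chain or an amine on this oxygen would behave also remains unknown.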